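This account rests on a few compounds, and the source may have more. Where it says the series, first, only, none or still open, it means among the compounds named here.

Measured compounds:
Compound 1, `CCCc1cc(O)cc(=O)n1Cc1ccc(-c2ccccc2-c2nn[nH]n2)cc1`, gives 0.048 mg/kg in a functional assay on the whole organism with Rattus norvegicus as the target; on this read-out lower numbers stand for an effect already at smaller amounts and higher numbers for an effect only at larger amounts of compound.
Compound 2, `CCCc1cc(OC)cc(=O)n1Cc1ccc(-c2ccccc2-c2nn[nH]n2)cc1`, gives 0.24 mg/kg in this assay.

Among the measured compounds shown here, compound 2 stands at the highest of the two numbers in this assay; its only neighbour is compound 1, which sits well below it. For the measured compounds named here, the single measured step, a 5.0-fold higher number from compound 1 to compound 2 (0.70 log units; beyond the scatter), came with methyl in place of hydrogen on an oxygen on an aromatic ring, so the larger group at this position went with a higher number.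

Compound 3, `CCCc1cc(S)cc(=O)n1Cc1ccc(-c2ccccc2-c2nn[nH]n2)cc1`, differs from compound 2 by sulfanyl in place of methoxy on an aromatic carbon. Going by the values given here, the step that bears on it is the one from compound 1 to compound 2, taken in reverse: the new group, like the hydroxy group of compound 1, is a group of 1 heavy atom carrying one hydrogen-bond donor, although sulfur is not oxygen, and no measured compound shows how this assay treats a sulfanyl group.

Compound 3 is therefore expected to move back toward compound 1, with a 3.0-fold lower number from compound 2 to compound 3 (0.48 log units; beyond the scatter) as the estimated step. The estimate for compound 3 is 0.08 mg/kg, expected to lie between 0.03 mg/kg and 0.25 mg/kg.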

Compound 3, dose for 50% inhibition: 0.017 mg/kg
Compound 3: middle estimate off by 4.7-fold (0.67 log units), on the high side, and the stated range ends above it.
By their numbers in this assay, from the lowest: compound 3; then compound 1; then compound 2.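

At this position the number is not set by the methoxy-to-hydrogen contrast alone: in this assay the change to sulfanyl brought a 14-fold lower number from compound 2 to compound 3 (1.15 log units; beyond the scatter), a larger step than the one seen when the methyl was removed from the oxygen of compound 2. The atom carrying the hydrogen also matters, since sulfanyl in place of hydroxy, a swap that leaves the heavy-atom count of the group unchanged, still gave a 2.8-fold lower number from compound 1 to compound 3 (0.45 log units; beyond the scatter), and compound 3 now holds the lowest number of the series. The data give no measured reason for either step, so the change in the number can be described but not explained.

The compounds shown leave open whether a methylsulfanyl group would raise the number over sulfanyl as methoxy did over hydroxy, which would separate the effect of capping the group from that of the sulfur atom itself. They also leave open where an amine, a chlorine atom or a longer ether such as ethoxy would fall at this position, and whether the order seen here holds with a chain other than propyl on the core.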